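Swapping Methylsulfanyl for a Methylthiazole Ring

The source may hold more compounds than are shown below. What is called first, only, known or untested is meant among the compounds shown, and "the series" means these compounds.

Compound 1 `CCOC(=O)c1cnc(SC)nc1NN1C(=O)C=C(C)C1=O` was tested in a functional assay on Jurkat cells for inhibition of nuclear factor NF-kappa-B complex (Homo sapiens) (on this read-out higher numbers stand for weaker inhibition and lower numbers for stronger inhibition), where compound 1 gives 200 nM. Among the three measured compounds this is the second highest number. Compound 2 `CCOC(=O)c1cnc(-c2ccccc2)nc1NN1C(=O)C=C(C)C1=O` gives 100 nM, and compound 3 `CCOC(=O)c1cnc(-c2ccncc2)nc1NN1C(=O)C=C(C)C1=O` gives 6000 nM. Replacing methylsulfanyl with phenyl yields a 2.0-fold lower number from compound 1 to compound 2 (0.30 log units; within the scatter), whereas replacing it with pyridin-4-yl yields a 30-fold higher number from compound 1 to compound 3 (1.48 log units; beyond the scatter); comparing the two rings directly yields a 60-fold higher number from compound 2 to compound 3 (1.78 log units; beyond the scatter).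

Compound 4 `CCOC(=O)c1cnc(-c2csc(C)n2)nc1NN1C(=O)C=C(C)C1=O` differs from compound 1 in one place: 2-methyl-1,3-thiazol-4-yl in place of methylsulfanyl on an aromatic carbon. The entering group is an aromatic ring with a ring nitrogen, as in compound 3, but it is five-membered and also carries a sulfur, as the leaving methylsulfanyl did. Both earlier ring replacements bear on this step. An aromatic ring without a ring nitrogen barely moved the number, as a 2.0-fold lower number from compound 1 to compound 2 (0.30 log units; within the scatter) shows, while a ring with a nitrogen raised it sharply, as a 30-fold higher number from compound 1 to compound 3 (1.48 log units; beyond the scatter) shows. A rise beyond the scatter is therefore expected for compound 4 in this assay, though a smaller one than for compound 3, and the expected step is a 5.0-fold higher number from compound 1 to compound 4 (0.70 log units; beyond the scatter). The estimate for compound 4 is 1000 nM, within a range from 200 nM to 5000 nM.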

Compound 4, half-maximal inhibitory concentration: 8000 nM
The estimate for compound 4 lay 8.0-fold (0.90 log units) below the measured number; measured number above the stated range.
By their numbers in this assay, from the lowest: compounds 2 and 1 (each within the scatter of the next); then compounds 3 and 4 (each within the scatter of the next).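

In this assay, the sulfur that the thiazole shares with methylsulfanyl does not keep the number near that of compound 1: the change gives a 40-fold higher number from compound 1 to compound 4 (1.60 log units; beyond the scatter), and the comparison with the phenyl ring gives an 80-fold higher number from compound 2 to compound 4 (1.90 log units; beyond the scatter). The comparison with the pyridine ring gives a 1.3-fold higher number from compound 3 to compound 4 (0.12 log units; within the scatter), so the five-membered ring with its methyl group and the six-membered pyridin-4-yl ring cannot be told apart here, and the high number at this position no longer rests on compound 3 alone. Across these four compounds, the two rings with a ring nitrogen give the high numbers and the ring without one does not, with no compound going against this pattern, but nothing measured here explains it.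

Open, going by these compounds, is whether the ring nitrogen itself matters, since the thiazole also brings a methyl group and a sulfur, and a thiophen-3-yl ring, with sulfur but no ring nitrogen, would help to separate these features. Also open, on these data alone, is how a pyridin-3-yl ring, with its nitrogen elsewhere in the ring, or a non-aromatic group such as dimethylamino or morpholin-4-yl would behave at this position.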